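Sulfonyl for carbonyl on the pyrazoline nitrogen of the series

This account rests on a few compounds, and the source may have more. Where it says the series, first, only, none or still open, it means among the compounds named here.

Compound 1 `CN1CCN(c2ccc(C3=NN(C(=O)CCCl)C(c4ccc(N(C)C)cc4)C3)cc2)CC1` gives 2.4% in a functional assay on MDA-MB-231 cells (Homo sapiens) for inhibition, read by sulforhodamine B assay, tested at 10 uM; a lower number here means less inhibition, a higher number more inhibition at the concentration tested (going by the name of the read-out). It stands second highest of the three numbers: compound 2 `Cc1ccc(C(=O)N2N=C(c3ccc(N4CCN(C)CC4)cc3)CC2c2ccc(N(C)C)cc2)cc1` gives -0.7%, a number 3.1 percentage points lower from compound 1 to compound 2 (within the scatter), and compound 3 `Cc1ccc(S(=O)(=O)N2N=C(c3ccc(N4CCN(C)CC4)cc3)CC2c2ccc(N(C)C)cc2)cc1` gives 10.7%, a number 8.3 percentage points higher from compound 1 to compound 3 (within the scatter). Compound 4 `CN1CCN(c2ccc(C3=NN(S(=O)(=O)c4ccc(Br)cc4)C(c4ccc(N(C)C)cc4)C3)cc2)CC1` is not yet measured; it differs from compound 1 by (4-bromophenyl)sulfonyl in place of (2-chloroethyl)carbonyl on an amine nitrogen in a ring. The closest measured step is the carbonyl-to-sulfonyl exchange at the same ring nitrogen, a number 8.3 percentage points higher from compound 1 to compound 3 (within the scatter), and the parallel exchange a number 11.4 percentage points higher from compound 2 to compound 3 (beyond the scatter). A sulfonyl entering in place of a carbonyl is therefore expected to lift the number only slightly, a number 6.6 percentage points higher from compound 1 to compound 4 (within the scatter), a step about the size of the scatter. Compound 4 is estimated at 9%, within -2% to 20%.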

Compound 4, a percentage reported as inhibition, at one concentration (the size of the read-out at that concentration, not a potency): 23.7%
Compound 4: middle estimate off by 14.7 percentage points, on the low side; measured number outside the range, above it.
By their numbers in this assay, from the lowest: compounds 2, 1 and 3 (each within the scatter of the next, the first and the last beyond it); then compound 4.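

Going by these compounds alone, the group carried on the sulfonyl counts at this ring nitrogen, not the sulfonyl alone: bromo in place of methyl on an aromatic carbon gives a number 13 percentage points higher from compound 3 to compound 4 (beyond the scatter), a change the earlier compounds did not include. Against the carbonyl compounds, (4-bromophenyl)sulfonyl gives a number 21.3 percentage points higher from compound 1 to compound 4 (beyond the scatter) and a number 24.4 percentage points higher from compound 2 to compound 4 (beyond the scatter). Nothing at hand accounts for the rise with bromo.

Open, on these data alone, is whether chloro, methoxy or an amine in the place of bromo goes the same way. Also open, as far as these compounds go, is what 4-bromophenyl gives on a carbonyl instead of a sulfonyl.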